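Estimating compound 4 from its measured neighbours

This account rests on a few compounds, and the source may have more. Where it says the series, first, only, none or still open, it means among the compounds named here.

Values in an ADME assay on MRC5 cells (Homo sapiens) for cytotoxicity, read by fluorescence and resazurin assay, with a stated time of 3 days; a lower number here means a stronger inhibitor, a higher number a weaker inhibitor:
- Compound 1 `Cc1cn(C2CCN(Cc3cccc(Oc4ccc(Cl)cc4)c3)CC2)c(=O)[nH]c1=O`: 25100 nM
- Compound 2 `Cc1cn(C2CCN(Cc3cccc(Oc4cccc(F)c4)c3)CC2)c(=O)[nH]c1=O`: > 64000 nM, which is a limit of the assay and not a number
- Compound 3 `COc1ccc(Oc2cccc(CN3CCC(n4cc(C)c(=O)[nH]c4=O)CC3)c2)cc1`: 28000 nM

Only two of these results are true numbers, and they lie close together: a 1.1-fold higher number from compound 1 to compound 3 (0.05 log units; within the scatter). The comparison with the limit shows a larger gap: an at least 2.2-fold lower number from compound 2 to compound 3 (0.35 log units; beyond the scatter).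

Compound 4 `Cc1cn(C2CCN(Cc3cccc(Oc4ccc(Cl)c(Cl)c4)c3)CC2)c(=O)[nH]c1=O` has one change from compound 3: 3,4-dichlorophenyl in place of 4-methoxyphenyl on an oxygen on an aromatic ring. This places 3,4-dichlorophenyl in place of 4-methoxyphenyl on an oxygen on an aromatic ring.

The closest guide is the chloro and methoxy comparison above, where the swap made no difference beyond the scatter. Compound 4 also carries the chloro group found in compound 1. As a caution, another change to this ring did matter: an at least 2.5-fold higher number from compound 1 to compound 2 (0.40 log units; beyond the scatter). No step beyond the scatter is therefore expected, with a slight lean towards a lower number. The expected step is a 1.3-fold lower number from compound 3 to compound 4 (0.10 log units; within the scatter). The estimate for compound 4 is 22000 nM, with an expected range from 10000 nM to 48000 nM.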

Compound 4, half-maximal inhibitory concentration: 6100 nM
For compound 4 the middle estimate is 3.6-fold (0.56 log units) above the measured one, outside the stated range (below it).
By their numbers in this assay, from the lowest: compound 4; then compounds 1 and 3 (each within the scatter of the next). At a limit, above all of these: compound 2.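

Among the earlier compounds, 4-chlorophenyl and 4-methoxyphenyl on this oxygen could not be told apart, so the ring seemed indifferent to that exchange. In this assay, among these compounds, adding one more chlorine does move the result, with a 4.1-fold lower number from compound 1 to compound 4 (0.61 log units; beyond the scatter) as the cleanest comparison, since chloro in place of hydrogen is the only change, and the exchange for 4-methoxyphenyl gives a similar shift, a 4.6-fold lower number from compound 3 to compound 4 (0.66 log units; beyond the scatter). Compound 2 gives a limit of the assay and not a number, so an at least 10-fold lower number from compound 2 to compound 4 (1.02 log units; beyond the scatter) is only a minimum: the limit of > 64000 nM in this assay, at which 1 of the 4 values shown sits.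

The compounds shown cannot tell whether the added chlorine acts alone or only together with the first. Going by these compounds, it also stays open whether 3-chlorophenyl, or a ring carrying an amine or a carboxylic acid in place of the chlorines, would give a similar number.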